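Chain lengthening on the enamide in a cervical-cell series

The source may hold more compounds than are shown below. What is called first, only, known or untested is meant among the compounds shown, and "the series" means these compounds.

Compound 1 `C/C=C/C(=O)Nc1cccc(Oc2nc(Nc3cccc(OC)c3)nc3c2CSCC3)c1` gives 13800 nM in a functional assay on HeLa cells (Homo sapiens) for antiproliferative activity, read by MTT assay, with a stated time of 72 h; a lower number here means a stronger inhibitor, a higher number a weaker inhibitor. Compound 2 `CC/C=C/C(=O)Nc1cccc(Oc2nc(Nc3cccc(OC)c3)nc3c2CSCC3)c1` carries methyl in place of hydrogen on a saturated chain carbon bound to a double-bonded chain carbon and gives 27200 nM in this assay; the step is a 2.0-fold higher number from compound 1 to compound 2 (0.29 log units; within the scatter). Compound 3 `CC/C=C/C(=O)Nc1cccc(Oc2nc(Nc3cccc(C#N)c3)nc3c2CSCC3)c1` gives 31800 nM; the step is a 1.2-fold higher number from compound 2 to compound 3 (0.07 log units; within the scatter). The values of compound 3 and compound 1 lie beyond the scatter of each other; the difference between the two cores is not broken down here.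

Compound 4 `CCC/C=C/C(=O)Nc1cccc(Oc2nc(Nc3cccc(C#N)c3)nc3c2CSCC3)c1` is not yet measured. Relative to compound 3 it carries methyl in place of hydrogen on a saturated chain carbon, two bonds along the chain from a double-bonded chain carbon. This is the same kind of change as from compound 1 to compound 2, not the same: there the carbon was bound to a double-bonded chain carbon, here it is two bonds along the chain from one. The earlier step of a 2.0-fold higher number from compound 1 to compound 2 (0.29 log units; within the scatter) stayed within the scatter, so a step of like size is expected here. The expected step is a 1.4-fold higher number from compound 3 to compound 4 (0.15 log units; within the scatter). Compound 4 is estimated at 45000 nM, with a range from 20000 nM to 100000 nM.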

Compound 4, half-maximal inhibitory concentration: 7220 nM
Compound 4: the middle estimate sits 6.2-fold (0.79 log units) above what was measured; measured number outside the range, below it.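

In this assay, methyl in place of hydrogen on a saturated chain carbon, two bonds along the chain from a double-bonded chain carbon, gives a 4.4-fold lower number from compound 3 to compound 4 (0.64 log units; beyond the scatter). Set beside the earlier chain step, this change does not carry over from one core to the other with a single size or direction: the same change on two cores in this assay, a 2.0-fold higher number (0.29 log units; within the scatter) from compound 1 to compound 2 and a 4.4-fold lower number (0.64 log units; beyond the scatter) from compound 3 to compound 4, 8.7-fold (0.94 log units) apart, beyond the scatter of two such steps. The two steps differ both in the core and in the chain carbon that takes the methyl, and one step per core cannot separate these two differences.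

From the compounds shown here alone, it remains open how the pent-1-en-1-yl chain reads on the core of compound 1. Also open, going by these compounds, is whether a longer chain, or an amine on that chain, would keep the lower number seen for compound 4.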